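Swapping the dichlorophenyl arm for a chloro-nitro arm

The source may hold more compounds than are shown below. What is called first, only, known or untested is meant among the compounds shown, and "the series" means these compounds.

Compound 2 `O=C(/C=C/c1ccc(Cl)c(Cl)c1)/C=C/c1ccccc1Oc1ncnc2ccc(Cl)cc12` and compound 1 `O=C(/C=C/c1ccccc1Oc1ncnc2ccc(Cl)cc12)/C=C/c1cccc(Cl)c1Cl` share a core and differ only in the aryl group on one end of the chain. In a functional assay on MGC-803 cells (Homo sapiens) for inhibition, read by MTT assay, with a stated time of 72 h (on this read-out lower numbers stand for stronger inhibition and higher numbers for weaker inhibition), compound 1 gives 5210 nM, while compound 2 gives 16200 nM, the highest of the two numbers recorded, which means the weakest inhibition seen so far. Among the compounds with values here, the step of a 3.1-fold higher number from compound 1 to compound 2 (0.49 log units; beyond the scatter) is the only measured step, and it swaps one dichlorophenyl for another.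

Compound 3 `O=C(/C=C/c1cc([N+](=O)[O-])ccc1Cl)/C=C/c1ccccc1Oc1ncnc2ccc(Cl)cc12` changes this same position again: 2-chloro-5-nitrophenyl in place of 3,4-dichlorophenyl on a double-bonded chain carbon bound to a double-bonded chain carbon. Within the data shown here, no measured step involves a nitro group, so the single step offers only a rough guide to how much this position can move the number. The expected step of a 2.0-fold lower number from compound 2 to compound 3 (0.31 log units; beyond the scatter) is a modest move toward stronger inhibition, with wide uncertainty. Compound 3 is therefore estimated at 8000 nM, within a range of 3000 nM to 25000 nM.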

Compound 3, half-maximal inhibitory concentration: 1960 nM
Compound 3: middle estimate off by 4.1-fold (0.61 log units), on the high side, outside the stated range (below it).
By their numbers in this assay, from the lowest: compound 3; then compound 1; then compound 2.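

In this assay the 2-chloro-5-nitrophenyl arm outdoes both dichlorophenyl arms, with an 8.3-fold lower number from compound 2 to compound 3 (0.92 log units; beyond the scatter) and with a 2.7-fold lower number from compound 1 to compound 3 (0.42 log units; beyond the scatter) and so compound 3 is the strongest inhibitor of the three. This position therefore tolerates more than a shift of the two chlorines, and the number can move further than the swap between dichlorophenyl arms alone suggested. The entering arm carries a nitro group with 2 hydrogen-bond acceptors and one chlorine, yet nothing measured here explains the gain.

Chlorine placement and the nitro group change together, so the compounds shown cannot separate their contributions. Also open, going by these compounds, is how an arm carrying an amine or a carboxylic acid in place of the nitro group would read in this assay at this position.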